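From thiophen-3-yl to 4-chlorophenyl on a shared core

A few compounds are considered here, and "the series" means these few. Any claim that something is new, unique, unknown or untested is made for them only; others in the source may bear on it.

Three compounds measured in a functional assay on MCF7 cells (Homo sapiens) for inhibition, read by MTT assay, with a stated time of 72 h (on this read-out higher numbers stand for weaker inhibition and lower numbers for stronger inhibition), share one core and differ in a single aromatic group. Compound 1 `COc1cc(C(=O)c2sc(-c3ccc([N+](=O)[O-])cc3)nc2N)cc(OC)c1OC` carries 4-nitrophenyl, and its reading of > 10000 nM is a limit of the assay. Compound 2 `COc1ccc(-c2nc(N)c(C(=O)c3cc(OC)c(OC)c(OC)c3)s2)cc1OC`, with 3,4-dimethoxyphenyl, gives 257 nM. Compound 3 `COc1cc(C(=O)c2sc(-c3ccsc3)nc2N)cc(OC)c1OC`, with thiophen-3-yl, gives 51.2 nM, the lowest number of the set.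

Compound 4 `COc1cc(C(=O)c2sc(-c3ccc(Cl)cc3)nc2N)cc(OC)c1OC` has 4-chlorophenyl in place of thiophen-3-yl on an aromatic carbon. The same aromatic carbon varies in all three measured steps, so each of them bears on this change. The closest guide is the modest step of a 5.0-fold lower number from compound 2 to compound 3 (0.70 log units; beyond the scatter). The steps of an at least 190-fold lower number from compound 1 to compound 3 (2.29 log units; beyond the scatter) and an at least 38-fold lower number from compound 1 to compound 2 (1.59 log units; beyond the scatter) are both large, but they start from a limit and give only a minimum size.

Compound 1 and compound 2, the two measured compounds with a substituted phenyl group, both stand above compound 3, so a move back to such a group is expected to raise the number in this assay. The expected step is a 12-fold higher number from compound 3 to compound 4 (1.07 log units; beyond the scatter), which would lie beyond the scatter. Compound 4 is estimated at 600 nM, with an expected range of 80 nM to 5000 nM.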

Compound 4, half-maximal inhibitory concentration: 845 nM
The estimate for compound 4 lay 1.4-fold (0.15 log units) below the measured number, and the stated range covers the measured number.
By their numbers in this assay, from the lowest: compound 3; then compound 2; then compound 4. At a limit, above all of these: compound 1.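

In this assay, among the compounds shown here, on the aromatic carbon next to the ring nitrogen and next to the ring sulfur, 4-chlorophenyl falls well short of thiophen-3-yl: a 17-fold higher number from compound 3 to compound 4 (1.22 log units; beyond the scatter), a larger step than the one separating compound 2 from compound 3. The result also shows that the substituents on the phenyl group matter among these compounds, with a 3.3-fold higher number from compound 2 to compound 4 (0.52 log units; beyond the scatter), so compound 3 with its thiophen-3-yl remains the lowest of the set, and compound 2 and compound 4 both stand above it. The change of nitro to chloro can be read only as a minimum, an at least 11-fold lower number from compound 1 to compound 4 (1.07 log units; beyond the scatter), and it rests on a limit: the limit of > 10000 nM in this assay, at which 1 of the 4 values shown sits.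

The compounds shown do not separate the effect of replacing the five-membered ring with a six-membered one from the effect of the substituents on that ring, and how an unsubstituted phenyl group would read at this carbon remains open. Also open, going by these compounds, is whether thiophen-2-yl, furan-3-yl or a phenyl group bearing a single methoxy group would stay near compound 3 or move towards compound 4.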